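Cyano for methoxy on the aniline ring: a lipophilicity step

A few compounds are considered here, and "the series" means these few. Any claim that something is new, unique, unknown or untested is made for them only; others in the source may bear on it.

Measured so far:
compound 1, `COc1ccc(NC[C@H](O)COc2ccc(N3C[C@H](CNC(C)=O)OC3=O)cc2F)cc1` — 0.95
compound 2, `COc1ccc(NC[C@@H](O)COc2ccc(N3C[C@H](CNC(C)=O)OC3=O)cc2F)cc1` — 1.15
compound 3, `CC(=O)NC[C@H]1CN(c2ccc(OC[C@@H](O)CNc3ccc(C#N)cc3)c(F)c2)C(=O)O1` — 2.12

Of the compounds shown here, three sharing one core have been measured in a physicochemical assay for lipophilicity, read by HPLC; on this read-out lower numbers stand for lower lipophilicity and higher numbers for higher lipophilicity. Compound 1 gives 0.95, compound 2 gives 1.15 and compound 3 gives 2.12. Compound 2 stands second highest of the three: its nearest neighbour is compound 1, with a number 0.20 log units higher from compound 1 to compound 2 (within the scatter), which is within the scatter and fits (the fact that compounds 1 and 2 differ only in the configuration as drawn); its furthest is compound 3, whose value lies well beyond the scatter above it.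

The unmeasured compound 4 is `CC(=O)NC[C@H]1CN(c2ccc(OC[C@H](O)CNc3ccc(C#N)cc3)c(F)c2)C(=O)O1`. Against compound 2 it shows (cyano in place of methoxy on an aromatic carbon).

Among the compounds with values here, one measured step bears directly on this change: a number 1.17 log units higher from compound 1 to compound 3 (beyond the scatter). That step is the same replacement, cyano in place of methoxy on an aromatic carbon, made on the other configuration of the chain carbon. Since the configuration step itself, a number 0.20 log units higher from compound 1 to compound 2 (within the scatter), was within the scatter, the cyano step is expected to carry over in size and direction. The expected step is a number 1.17 log units higher from compound 2 to compound 4 (beyond the scatter), well beyond the scatter. Compound 4 is therefore estimated at 2.32, with a range from 2 to 2.65.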

Compound 4, partition coefficient: 1.29
For compound 4 the middle estimate is 1.03 log units above the measured one, and the stated range ends above it.
By their numbers in this assay, from the lowest: compounds 1, 2 and 4 (each within the scatter of the next, the first and the last beyond it); then compound 3.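

In this assay, cyano in place of methoxy on the aromatic carbon now gives a number 0.14 log units higher from compound 2 to compound 4 (within the scatter), while the same replacement on the other configuration of the chain carbon gave a number 1.17 log units higher from compound 1 to compound 3 (beyond the scatter), so this replacement has no single size at this position. Configuration at the chain carbon, which gave a step within the scatter in the methoxy pair, now separates the cyano pair, with a number 0.83 log units lower from compound 3 to compound 4 (beyond the scatter) as the result. The two compounds of that pair have the same atoms and bonds, so this gap can be traced to the stereocentre alone: the fact that compounds 3 and 4 differ only in the configuration as drawn.

The compounds shown do not explain why the configuration counts in the cyano pair and not in the methoxy pair. Nor do they tell whether the same dependence on configuration would appear with another group on that aromatic carbon, such as an amine or a carboxylic acid, drawn in both configurations.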